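Trading the Ester Tail for a Hydroxyl Tail

This account rests on a few compounds, and the source may have more. Where it says the series, first, only, none or still open, it means among the compounds named here.

Compound 1 `CCOC(=O)CCCCOc1ccc2c(=O)c(-c3ccc(O)cc3)coc2c1` has the highest of the three numbers measured in an assay (Cricetulus griseus) for inhibition of aldehyde dehydrogenase, mitochondrial (Homo sapiens) (a higher number here means a weaker inhibitor, a lower number a stronger inhibitor), where compound 1 gives 240 nM. Compound 2 `NCCCCCCOc1ccc2c(=O)c(-c3ccc(O)cc3)coc2c1` gives 100 nM in this assay, and compound 3 `O=C(O)CCCCCCCCCCCOc1ccc2c(=O)c(-c3ccc(O)cc3)coc2c1` gives 130 nM; the gap from compound 1 to compound 3 is within the scatter. Compound 4 `O=c1c(-c2ccc(O)cc2)coc2cc(OCCCCCCO)ccc12` differs from compound 1 by 2-hydroxyethyl in place of ethoxycarbonyl on a saturated chain carbon, four bonds along the chain from an oxygen on an aromatic ring. For the measured compounds named here, two measured steps bear on this: a 2.4-fold lower number from compound 1 to compound 2 (0.38 log units; beyond the scatter) and a 1.8-fold lower number from compound 1 to compound 3 (0.27 log units; within the scatter). Both swap the ethoxycarbonyl for a chain carrying a hydrogen-bond donor, and neither raises the number. A small lowering is therefore expected for compound 4, a 1.6-fold lower number from compound 1 to compound 4 (0.20 log units; within the scatter). Compound 4 is estimated at 150 nM, with a range from 70 nM to 350 nM.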

Compound 4, half-maximal inhibitory concentration: 120 nM
Beside the measured number, compound 4's estimate is 1.3-fold (0.10 log units) above it, and the stated range covers the measured number.
By their numbers in this assay, from the lowest: compounds 2, 4, 3 and 1 (each within the scatter of the next, the first and the last beyond it).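

In this assay, the step to the hydroxyl tail, a 2.0-fold lower number from compound 1 to compound 4 (0.30 log units; within the scatter), stays within the scatter, so this swap at the chain end cannot be told apart from no change. The hydroxy end also sits level with the longer acid tail, a 1.1-fold lower number from compound 3 to compound 4 (0.03 log units; within the scatter), and with the amine, a 1.2-fold higher number from compound 2 to compound 4 (0.08 log units; within the scatter), so three quite different chain ends give matching numbers at this position. Nothing available explains this match. Still open, going by these compounds, is whether a methyl ether at the chain end, or a shorter chain ending in hydroxy, would stay in this range.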